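The source may report more compounds than this note shows. Statements on the series, on what has been measured and on what is new or still open speak of the compounds shown alone.

Four compounds built on one shared core are examined in an ADME assay on BJ cells (Homo sapiens) for cytotoxicity, read by CellTiter-Glo and resazurin assay, with a stated time of 72 h; on this read-out higher numbers stand for an effect only at larger amounts of compound and lower numbers for an effect already at smaller amounts. Compound 1 `CCCNCc1ccccc1OCCCCCC(=O)OCC` carries a (propylamino)methyl group on its aromatic ring. In this assay compound 1 gives > 26000 nM, which is a limit of the assay and not a number. Compound 2 `CCCNCc1ccc(OCCCCCC(=O)OCC)cc1` has the same atoms as compound 1, joined differently; the difference between the two cores is not broken down here. In this assay compound 2 gives > 26000 nM, again a limit rather than a number. Compound 3 `CCOC(=O)CCCCCOc1ccccc1C=O` arises from compound 1 by the change (formyl in place of (propylamino)methyl on an aromatic carbon). In this assay compound 3 gives > 26000 nM, also a limit and not a number. The measured step that the two limits leave unreadable from compound 1 to compound 3 cannot be read because of the limit of > 26000 nM in this assay, at which 3 of the 3 values shown sit.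

Compound 4 `CCOC(=O)CCCCCOc1ccc(C=O)cc1` is not yet measured; it arises from compound 2 by the change (formyl in place of (propylamino)methyl on an aromatic carbon). Among the measured compounds shown here, this is the same kind of change as the one leading to compound 3, though not the same: in compound 4 the formyl sits para to a large group, whereas in compound 3 it sits ortho to a large group. The expected step is a step that the limit leaves unreadable from compound 2 to compound 4, resting on a step that the two limits leave unreadable from compound 1 to compound 3, which itself stayed unreadable. In this assay compound 4 is therefore expected to give 40000 nM, within an expected range from 20000 nM to 100000 nM, with the most likely outcome being a further limit.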

Compound 4, half-maximal effective concentration: > 26000 nM
Compound 4 gave a limit, no number; the forecaster's own chance of this, stated with the estimate: 85%; the middle value is on the limit's open side.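

In this assay compound 4 gives > 26000 nM, which is a limit of the assay and not a number. No size can be read for the step from compound 2 to compound 4, because the result sits at the same limit as the others: the limit of > 26000 nM in this assay, at which 4 of the 4 values shown sit.

The compounds shown leave open whether formyl in place of (propylamino)methyl changes this read-out at all, and at what amount any of the four compounds would show an effect.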